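Swapping Dimethylamino for 1-Methyl-1H-pyrazol-4-yl

The compounds below may be only part of what the source reports. "The series", "measured", "known", "first", "only" and "open" are said of these compounds alone.

In a functional assay on A549 cells (Homo sapiens) for inhibition, read by CCK-8 assay, with a stated time of 48 h (a lower number here means a stronger inhibitor, a higher number a weaker inhibitor), compound 1 `COc1cc(-c2ccnc3cc(-c4ccccc4)nn23)cc(OC)c1OC` gives 208 nM, while compound 2 `COc1cc(-c2ccnc3cc(-c4ccc(N(C)C)cc4)nn23)cc(OC)c1OC` gives 1100 nM. Among the compounds with values here, compound 2 thus holds the higher, weaker of the only two numbers available. Compound 3 `COc1cc(-c2ccnc3cc(-c4ccc(-c5cnn(C)c5)cc4)nn23)cc(OC)c1OC` keeps the shared core and changes the substituent carried by compound 2: 1-methyl-1H-pyrazol-4-yl in place of dimethylamino on an aromatic carbon, para to a large group (1-methyl-1H-pyrazol-4-yl in place of dimethylamino on an aromatic carbon).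

Within the data shown here, only one measured step bears on this change: a 5.3-fold higher number from compound 1 to compound 2 (0.72 log units; beyond the scatter), a modest step beyond the scatter that came with dimethylamino in place of hydrogen on an aromatic carbon. Among the measured compounds shown here, it shows that a substituent at this place can shift the number, but no measured compound carries the new group, so the direction remains uncertain. With compound 2 at the weak end of the measured values, a partial return towards compound 1 seems the likeliest outcome. The expected change is a 2.2-fold lower number from compound 2 to compound 3 (0.34 log units; beyond the scatter), smaller than the measured step. For compound 3, the estimated value is 500 nM, with an expected range of 120 nM to 2000 nM.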

Compound 3, half-maximal inhibitory concentration: 1150 nM
Compound 3: the middle estimate sits 2.3-fold (0.36 log units) below what was measured; low and high end bracket the measured number.
By their numbers in this assay, from the lowest: compound 1; then compounds 2 and 3 (each within the scatter of the next).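

In this assay, 1-methyl-1H-pyrazol-4-yl in place of dimethylamino gave a 1.0-fold higher number from compound 2 to compound 3 (0.02 log units; within the scatter), so at this position a group of 6 heavy atoms with a five-membered aromatic ring cannot be told apart from one of 3 heavy atoms with no ring. Against hydrogen, the new group gave a 5.5-fold higher number from compound 1 to compound 3 (0.74 log units; beyond the scatter), a step beyond the scatter, as was a 5.3-fold higher number from compound 1 to compound 2 (0.72 log units; beyond the scatter), so among these three compounds both substituents on this aromatic carbon give a higher number than hydrogen, and neither brings the value back towards that of compound 1. No available evidence bears on this result.

The compounds shown leave open whether any group on this carbon raises the number, or only these two, since neither a fluorine atom nor a methoxy group appears here. They also leave open how an amine joined through a longer chain or a carboxylic acid in the same place would compare with compound 1.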